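This account rests on a few compounds, and the source may have more. Where it says the series, first, only, none or still open, it means among the compounds named here.

In a functional assay on HEK293 cells for antagonist activity at transient receptor potential cation channel subfamily V member 1 (Homo sapiens), read by calcium flux (on this read-out lower numbers stand for stronger inhibition and higher numbers for weaker inhibition), compound 1 `FC(F)(F)c1ccc(Nc2ncnc3sc(Nc4c(Cl)cccc4Cl)nc23)cc1` gives 12 nM, while compound 2 `Clc1cccc(Cl)c1Nc1nc2c(Nc3ccccc3)ncnc2s1` gives 176 nM; of the two numbers measured in this assay, compound 2 holds the higher one, and the step of a 15-fold higher number from compound 1 to compound 2 (1.17 log units; beyond the scatter) lies beyond the scatter. Compound 3 `Cc1ccc(Nc2ncnc3sc(Nc4c(Cl)cccc4Cl)nc23)cc1` is not yet measured. It differs from compound 2 by methyl in place of hydrogen on an aromatic carbon. Among the measured compounds shown here, the only measured step that bears on this position is the one from compound 1 to compound 2, where removing a trifluoromethyl from the same carbon raised the number by a large amount. Putting a methyl there reverses that direction, though with a different group, so the number for compound 3 is expected to fall again, by a step of a 3.5-fold lower number from compound 2 to compound 3 (0.55 log units; beyond the scatter) that is smaller than the one seen before. The estimate for compound 3 in this assay is 50 nM, with a likely range from 15 nM to 150 nM.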

Compound 3, half-maximal inhibitory concentration: 33 nM
Estimate against measurement, compound 3: 1.5-fold (0.18 log units) above, within the range that was stated.
By their numbers in this assay, from the lowest: compound 1; then compound 3; then compound 2.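

In this assay, this carbon para to a large group does not need trifluoromethyl for much of the gain: a single methyl already gives a 5.3-fold lower number from compound 2 to compound 3 (0.73 log units; beyond the scatter). Trifluoromethyl still keeps an edge over methyl, with a 2.8-fold higher number from compound 1 to compound 3 (0.44 log units; beyond the scatter), so the identity of the group matters as well as whether the carbon carries hydrogen, and the three compounds now fall in the order trifluoromethyl, methyl, hydrogen from lowest number to highest. Nothing available here accounts for the gains or for the gap between the two groups.

Among the compounds shown here, with only three groups at one carbon, no trend can be drawn that would predict a chlorine, a methoxy, an amine or a longer chain such as tert-butyl. Going by these compounds, it also remains open whether methyl or trifluoromethyl would give similar steps on another carbon of this ring.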